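Swapping a ring for an open chain

The source may report more compounds than this note shows. Statements on the series, on what has been measured and on what is new or still open speak of the compounds shown alone.

Compound 1 `O=S(=O)(/C=C/c1ccc(O)c(O)c1)CCCCCCCO`: 5900 nM
Compound 2 `O=S(=O)(/C=C/c1ccc(O)c(O)c1)CC1CCCCO1`: 10800 nM
Compound 3 `O=S(=O)(/C=C/c1ccc(O)c(O)c1)CC1CCCO1`: 10500 nM

All three compounds were tested in a functional assay, read by fluorescence and spectrophotometry, with a stated time of 1 h; on this read-out lower numbers stand for an effect already at smaller amounts and higher numbers for an effect only at larger amounts of compound. The numbers do not set compound 3 apart from the other two, as the data show a 1.0-fold lower number from compound 2 to compound 3 (0.01 log units; within the scatter) and a 1.8-fold higher number from compound 1 to compound 3 (0.25 log units; within the scatter).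

The next compound, compound 4 `CCCCCCCCS(=O)(=O)/C=C/c1ccc(O)c(O)c1`, has not yet been measured. It carries heptyl in place of oxolan-2-yl on a saturated chain carbon bound to a sulfonyl sulfur. For the measured compounds named here, no measured compound carries heptyl, so the closest guides are the steps that exchange an open chain for a ring. These are a 1.8-fold higher number from compound 1 to compound 3 (0.25 log units; within the scatter) and a 1.8-fold higher number from compound 1 to compound 2 (0.26 log units; within the scatter), and neither clears the scatter. Going by the values given here, compound 1, the only measured compound with an open chain in this place, gives 5900 nM. In this assay, a modest shift at most is therefore expected, and none beyond the scatter. The estimated step is a 1.5-fold lower number from compound 3 to compound 4 (0.18 log units; within the scatter). The estimate for compound 4 is 7000 nM, with an expected range of 3000 nM to 14000 nM.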

Compound 4, half-maximal effective concentration: 6400 nM
For compound 4 the middle estimate is 1.1-fold (0.04 log units) above the measured one; low and high end bracket the measured number.
By their numbers in this assay, from the lowest: compounds 1, 4, 3 and 2 (each within the scatter of the next).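

The ring is not needed at this place: the data show a 1.6-fold lower number from compound 3 to compound 4 (0.22 log units; within the scatter) and a 1.7-fold lower number from compound 2 to compound 4 (0.23 log units; within the scatter), so in this assay exchanging either ring for heptyl, an all-carbon open chain, leaves the number within the usual scatter. The hydroxy at the end of the chain of compound 1 makes no readable difference either, as methyl in its place gives a 1.1-fold higher number from compound 1 to compound 4 (0.04 log units; within the scatter), and so all four groups seen here, open or ringed, with or without oxygen, read alike. No separate evidence bears on this result.

From the compounds shown here alone, it remains open whether a group of another kind at this place, such as an amine or a carboxylic acid, would move the number beyond the scatter. The same question stands for a longer chain than heptyl.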